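Amide aryl swap on a shared quinoline-acetamide core

The source may report more compounds than this note shows. Statements on the series, on what has been measured and on what is new or still open speak of the compounds shown alone.

Measured so far:
compound 1 `CC(=O)Nc1cccc2c(-c3cccc(NC(=O)c4cccc(C(F)(F)F)c4)c3)ccnc12` – 8000 nM
compound 2 `CC(=O)Nc1cccc2c(-c3cccc(NC(=O)c4ccc5c(c4)OCCO5)c3)ccnc12` – 570 nM

In a functional assay on A375P cells (Homo sapiens) for antiproliferative activity, read by MTT assay, with a stated time of 48 h (on this read-out lower numbers stand for stronger inhibition and higher numbers for weaker inhibition), compound 2 gives the lowest of the two numbers, with compound 1 giving 8000 nM as its nearest neighbour. Compound 3 `CC(=O)Nc1cccc2c(-c3cccc(NC(=O)c4cc5ccccc5s4)c3)ccnc12` differs from compound 2 by 1-benzothiophen-2-yl in place of 2,3-dihydro-1,4-benzodioxin-6-yl on a carbonyl carbon. Going by the values given here, no measured step follows this exact change; the only step at that carbonyl carbon, a 14-fold lower number from compound 1 to compound 2 (1.15 log units; beyond the scatter), shows that the aryl group there matters strongly. Compound 3 is therefore expected to move by a 2.6-fold higher number from compound 2 to compound 3 (0.42 log units; beyond the scatter), toward a weaker read-out, with wide uncertainty. Compound 3 is estimated at 1500 nM, between 300 nM and 8000 nM.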

Compound 3, half-maximal inhibitory concentration: 9100 nM
The estimate for compound 3 lay 6.1-fold (0.78 log units) below the measured number; the measured number lies above the stated range.
By their numbers in this assay, from the lowest: compound 2; then compounds 1 and 3 (each within the scatter of the next).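

The step of a 16-fold higher number from compound 2 to compound 3 (1.20 log units; beyond the scatter) in this assay shows that a second group with two rings on this carbonyl carbon does not keep the number of compound 2. The step of a 1.1-fold higher number from compound 1 to compound 3 (0.06 log units; within the scatter) puts 1-benzothiophen-2-yl level with 3-(trifluoromethyl)phenyl, so compound 2 stands alone at the low end of these three. No measurement shown here explains this difference. Open, on these data alone, is whether the number of compound 2 depends on the oxygen atoms of its 2,3-dihydro-1,4-benzodioxin-6-yl group, and whether a phenyl ring carrying a methoxy group or a morpholine would hold that number.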